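Ester chain extension on the shared chromone-type core

A few compounds are considered here, and "the series" means these few. Any claim that something is new, unique, unknown or untested is made for them only; others in the source may bear on it.

Compound 1 `CCCCCCc1c(F)c(N)c2c(=O)cc(-c3ccc(N)c(F)c3)oc2c1F` and compound 2 `CCCCCC(=O)OCc1c(F)c(N)c2c(=O)cc(-c3ccc(N)c(F)c3)oc2c1F` differ only in the side chain. In a functional assay on MCF7 cells (Homo sapiens) for cytotoxicity, read by neutral red uptake, with a stated time of 3 days (a higher number here means a weaker inhibitor, a lower number a stronger inhibitor), compound 1 gives > 10000 nM, which is a limit of the assay and not a number. In this assay, among the compounds with values here, compound 2 gives 160 nM; this is the only number. The value of compound 1 is a limit (the limit of > 10000 nM in this assay, at which 1 of the 2 values shown sits). Within the data shown here, the single measured step is an at least 62-fold lower number from compound 1 to compound 2 (1.79 log units; beyond the scatter). Compound 3 `CCCCCCCCCCCCCCCCCC(=O)OCc1c(F)c(N)c2c(=O)cc(-c3ccc(N)c(F)c3)oc2c1F` differs from compound 2 by dodecyl in place of hydrogen on a saturated chain carbon, five bonds along the chain from a carbonyl carbon. Among the measured compounds shown here, the measured step exchanged pentyl for (pentylcarbonyl)oxy and does not address lengthening the ester chain while the ester itself is kept, so no measured step bears directly on the change to compound 3; the expectation rests on compound 2 alone. The step is therefore expected to be a 2.5-fold higher number from compound 2 to compound 3 (0.40 log units; beyond the scatter), with a wide range. Compound 3 is expected to give 400 nM in this assay, between 100 nM and 4000 nM.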

Compound 3, half-maximal inhibitory concentration: > 10000 nM
Compound 3: a limit, no number (the forecaster's own chance of this, stated with the estimate: 15%); at least 25-fold (1.39 log units) between middle value and limit.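

In this assay compound 3 gives > 10000 nM, which is a limit of the assay and not a number. The ester alone therefore does not carry the activity: adding dodecyl on the saturated chain carbon, five bonds along the chain from a carbonyl carbon, gives an at least 62-fold higher number from compound 2 to compound 3 (1.79 log units; beyond the scatter), so the length of the chain on the ester matters as well. The series now reaches the limit both without the ester in compound 1 and with the dodecyl extension in compound 3: the limit of > 10000 nM in this assay, at which 2 of the 3 values shown sit.

Where the activity is lost along the chain remains open, and an octanoyl or dodecanoyl ester would help locate that point. Also open, going by these compounds, is whether an amide in place of the ester, or a shorter acetyl ester, would keep the activity of compound 2.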